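A few compounds are considered here, and "the series" means these few. Any claim that something is new, unique, unknown or untested is made for them only; others in the source may bear on it.

Measured so far:
Compound 1, `Cc1nn(C)c2nc(NNC(=O)Nc3cc(Cl)nc(Cl)c3)cc(C3CC3)c12`: 3650 nM in an assay on isolated protein for binding affinity to sphingosine 1-phosphate receptor 2 (Homo sapiens), read by surface plasmon resonance; a higher number here means weaker binding, a lower number tighter binding
Compound 2, `COc1cc(NC(=O)NNc2cc(-c3ccc(F)cc3)c3cnn(C)c3n2)cc(OC)c1OC`: 4440 nM in this assay

Compound 1 gives the lower of these two numbers, yet the gap to compound 2 lies within the scatter, so the two cannot be told apart. Compound 3, `Cc1nn(C)c2nc(NNC(=O)Nc3cc(Cl)nc(Cl)c3)cc(-c3ccccc3)c12`, is not yet measured. It differs from compound 1 in one place: phenyl in place of cyclopropyl on an aromatic carbon. Among the measured compounds shown here, no measured pair shows the effect of such a swap, so no step beyond the scatter is expected in either direction. In this assay a change of a 1.2-fold lower number from compound 1 to compound 3 (0.09 log units; within the scatter) is expected. Compound 3 is estimated at 3000 nM, within a range from 1000 nM to 9000 nM.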

Compound 3, dissociation constant: 5320 nM
Compound 3: middle estimate off by 1.8-fold (0.25 log units), on the low side; the range from low to high includes it.
By their numbers in this assay, from the lowest: compounds 1, 2 and 3 (each within the scatter of the next).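

In this assay, phenyl in place of cyclopropyl on this aromatic carbon gives a 1.5-fold higher number from compound 1 to compound 3 (0.16 log units; within the scatter). Among the compounds shown here, this position therefore takes a ring of 6 heavy atoms instead of one of 3 with no step that can be told apart from repeat-measurement noise. Nothing measured here bears on the reason for this result.

Both groups at this position are carbon-only rings with no hydrogen-bond donors or acceptors. As far as these compounds go, whether an amine or a carboxylic acid there would shift binding beyond the scatter remains open.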